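From a Pyrazinyl Amide to a Bromophenyl Amide

The source may report more compounds than this note shows. Statements on the series, on what has been measured and on what is new or still open speak of the compounds shown alone.

Compound 1 `CCN(CC)c1cc2[nH]c(C3CCCCC3)nc2cc1NC(=O)c1cnccn1` carries a pyrazin-2-yl amide on the shared core. In an ADME assay on Vero cells (Chlorocebus sabaeus) for cytotoxicity, read by resazurin assay, with a stated time of 3 days (on this read-out lower numbers stand for stronger inhibition and higher numbers for weaker inhibition), compound 1 gives > 100 ug/mL, which is a limit of the assay rather than a number. Two further compounds on the same core are known in this assay. Compound 2 `CCOCCOC(=O)Nc1cc2nc(C3CCCCC3)[nH]c2cc1N(C)C` gives > 100 ug/mL, again only a limit. Compound 3 `CCCCOC(=O)Nc1cc2nc(C3CCCCC3)[nH]c2cc1N(C)C` gives > 100 ug/mL, also a limit. For the measured compounds named here, the one step between measured compounds that differ in a single place, a step that the two limits leave unreadable from compound 2 to compound 3, therefore has no readable size, and the whole picture rests on (the limit of > 100 ug/mL in this assay, at which 3 of the 3 values shown sit).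

Compound 4 `CCN(CC)c1cc2[nH]c(C3CCCCC3)nc2cc1NC(=O)c1ccc(Br)cc1` is the partner of compound 1 with 4-bromophenyl in place of pyrazin-2-yl on a carbonyl carbon. Going by the values given here, no measured step touches the amide carbonyl substituent, and the one step that exists cannot be sized, so there is nothing in the data that would place compound 4 away from the limit where compound 1 sits. The expected step of a number no higher from compound 1 to compound 4 (the limit leaves the size open) is therefore no step beyond the scatter. Compound 4 is expected to give about 100 ug/mL in this assay, in a range from 40 ug/mL to 300 ug/mL, most probably reported as a limit once more.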

Compound 4, half-maximal inhibitory concentration: > 100 ug/mL
Compound 4: a limit, no number; the forecaster's own chance of this, stated with the estimate: 75%; the middle value sits exactly at the limit.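

In this assay compound 4 gives > 100 ug/mL, which is a limit and not a number. No step can be read between compound 1 and compound 4, because both stand at a limit: the limit of > 100 ug/mL in this assay, at which 4 of the 4 values shown sit.

The compounds shown leave open how far any of them lies from that limit, and whether 4-bromophenyl and pyrazin-2-yl on a carbonyl carbon differ at all in this assay.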